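This account rests on a few compounds, and the source may have more. Where it says the series, first, only, none or still open, it means among the compounds named here.

Measured compounds:
compound 1, `COc1ccccc1/C=c1/[nH]c(=O)/c(=C\c2ccccc2OC)[nH]c1=O`: "not active" (no number reported)
compound 2, `COc1ccccc1/C=c1\c(=O)[nH]/c(=C/c2cccc(Cl)c2Cl)c(=O)n1C`: 110 nM

The account concerns two compounds measured in a functional assay on K562 cells (Homo sapiens) for cytotoxicity, read by CCK-8 assay, with a stated time of 72 h (on this read-out lower numbers stand for stronger inhibition and higher numbers for weaker inhibition), and another compound that has not yet been tested. Compound 1 `COc1ccccc1/C=c1/[nH]c(=O)/c(=C\c2ccccc2OC)[nH]c1=O` has no single number on this read-out: in this assay compound 1 is recorded as "not active" (no number reported). Compound 2 `COc1ccccc1/C=c1\c(=O)[nH]/c(=C/c2cccc(Cl)c2Cl)c(=O)n1C` does carry a number: in this assay compound 2 gives 110 nM, which shows that a compound of this general type can reach the low nanomolar range.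

The step under study leads from compound 1 to compound 3 `C=CCn1c(=O)/c(=C\c2ccccc2OC)[nH]c(=O)/c1=C\c1ccccc1OC`. The change is allyl in place of hydrogen on an aromatic nitrogen. Among the measured compounds shown here, no measured pair shows this particular change, so its size cannot be read from the data. Because compound 1 stands at "not active" (no number reported), any number at all for compound 3 would register as a move toward stronger inhibition, and that is the direction expected, though the extent is uncertain. Compound 3 is estimated at 4000 nM in this assay, within a range of 500 nM to 30000 nM.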

Compound 3, half-maximal inhibitory concentration: 7400 nM
Compound 3: middle estimate off by 1.9-fold (0.27 log units), on the low side, and the stated range covers the measured number.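

In this assay, among the compounds shown here, compound 1 is recorded as "not active" (no number reported), with no number, so no step from it to compound 3 can be read. The compounds shown leave open how large a change allyl in place of hydrogen on the aromatic nitrogen brings. Nothing at hand bears on the cause of this result.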